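The source may hold more compounds than are shown below. What is called first, only, known or untested is meant among the compounds shown, and "the series" means these compounds.

Of the compounds shown here, two with a shared core have been measured so far in a functional assay on MCF7 cells (Homo sapiens) for inhibition, read by sulforhodamine B assay, with a stated time of 48 h; on this read-out lower numbers stand for stronger inhibition of growth and higher numbers for weaker inhibition of growth. Compound 1 `O=C(NNC(=O)c1ccc2[nH]c(-c3ccc([N+](=O)[O-])o3)nc2c1)c1ccccc1` gives 62.5 ug/mL, while compound 2 `COc1cccc(C(=O)NNC(=O)c2ccc3[nH]c(-c4ccc([N+](=O)[O-])o4)nc3c2)c1` gives 15.6 ug/mL, the lower of the two numbers and so the stronger growth inhibition of this small pair. For the measured compounds named here, the only measured step, a 4.0-fold lower number from compound 1 to compound 2 (0.60 log units; beyond the scatter), comes with methoxy in place of hydrogen on an aromatic carbon. It is modest, but beyond the usual scatter.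

The next case is compound 3 `O=CNNC(=O)c1ccc2[nH]c(-c3ccc([N+](=O)[O-])o3)nc2c1`, which differs from compound 2 as follows: hydrogen in place of 3-methoxyphenyl on a carbonyl carbon. This is hydrogen in place of 3-methoxyphenyl on a carbonyl carbon, so the whole group leaves, not just its methoxy. Going by the values given here, no measured step removes that group, which makes the guide a weak one. The methoxy-bearing compound 2 sits lower through the step of a 4.0-fold lower number from compound 1 to compound 2 (0.60 log units; beyond the scatter), and that methoxy now leaves, so a move to a higher number of similar or smaller size seems likely. The expected change is a 2.0-fold higher number from compound 2 to compound 3 (0.30 log units; within the scatter). For compound 3 the estimated value in this assay is 31 ug/mL, with an expected range from 10 ug/mL to 125 ug/mL.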

Compound 3, concentration for 50% growth inhibition: 62.5 ug/mL
For compound 3 the middle estimate is 2.0-fold (0.30 log units) below the measured one, and the stated range covers the measured number.
By their numbers in this assay, from the lowest: compound 2; then compounds 1 and 3 (each within the scatter of the next).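

In this assay, the whole 3-methoxyphenyl group on the carbonyl carbon gives way to hydrogen with a 4.0-fold higher number from compound 2 to compound 3 (0.60 log units; beyond the scatter) and this shows that the lower number of compound 2 is lost once that group is gone. Replacing plain phenyl with hydrogen at the same carbon adds something new, with no change at the digits printed from compound 1 to compound 3 (within the scatter) as the result, so among these compounds a phenyl ring without methoxy reads the same as hydrogen here, and only the 3-methoxyphenyl ring of compound 2 stands apart from the other two. Nothing available here explains this difference in growth inhibition.

Going by these compounds, it remains open whether methoxy itself matters or whether another group on that ring, such as a hydroxyl or a chlorine, would lower the number as well. Also open, on these data alone, is how the carbonyl carbon would respond to something that is neither hydrogen nor an aromatic ring, such as a methyl group, a longer alkyl chain or an amine.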